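Pyridin-2-yl in place of 4-fluorophenyl: compound 3

The compounds below may be only part of what the source reports. "The series", "measured", "known", "first", "only" and "open" are said of these compounds alone.

Measured compounds:
- compound 1, `C=C1C[C@]23C[C@@]1(O)CC[C@H]2c1cc(Br)c(O)c(C)c1[C@@H]3Cn1cc(-c2ccc(OC)cc2)nn1`; in a functional assay on A549 cells (Homo sapiens) for cytotoxicity, read by MTT assay, with a stated time of 4 days (on this read-out lower numbers stand for stronger inhibition and higher numbers for weaker inhibition), compound 1 reaches only the limit > 20000 nM
- compound 2, `C=C1C[C@]23C[C@@]1(O)CC[C@H]2c1cc(Br)c(O)c(C)c1[C@@H]3Cn1cc(-c2ccc(F)cc2)nn1`; in this assay compound 2 gives 17900 nM

Among the measured compounds shown here, compound 2 holds the only actual number in this assay; the other entry is a limit, (the limit of > 20000 nM in this assay, at which 1 of the 2 values shown sits). For the measured compounds named here, the single measured step, an at least 1.1-fold lower number from compound 1 to compound 2 (0.04 log units; that floor lies within the scatter), has its floor within the scatter and says little about direction.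

Compound 3, `C=C1C[C@]23C[C@@]1(O)CC[C@H]2c1cc(Br)c(O)c(C)c1[C@@H]3Cn1cc(-c2ccccn2)nn1`, differs from compound 2 by pyridin-2-yl in place of 4-fluorophenyl on an aromatic carbon. Going by the values given here, the one measured step concerns a substituent on the phenyl ring, not the exchange of that ring for a nitrogen-bearing one, so it bears on the new step only loosely. With no step beyond the scatter in hand, the expectation for this assay is no change beyond the scatter, and a fair chance that only a limit comes back.

The estimate for compound 3 is 18000 nM, within 8000 nM to 40000 nM, corresponding to an expected step of a 1.0-fold higher number from compound 2 to compound 3 (0.00 log units; within the scatter).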

Compound 3, half-maximal inhibitory concentration: > 20000 nM
Compound 3: a limit, no number (the forecaster's own chance of this, stated with the estimate: 40%); middle value at least 1.1-fold (0.04 log units) from the limit.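

Pyridin-2-yl in place of 4-fluorophenyl brings the first ring with a hetero atom to this position, and in this assay it gives an at least 1.1-fold higher number from compound 2 to compound 3 (0.04 log units; that floor lies within the scatter). This change therefore shows no readable gain over the carbon-only ring of compound 2, and the floor of the step does not fix how large any loss might be; the step between compound 1 and compound 3 cannot be read, as both values are limits. The aryl exchanges now leave most of the series at the top of the measurable range: the limit of > 20000 nM in this assay, at which 2 of the 3 values shown sit.

Going by these compounds, how far compound 3 lies beyond its limit remains open. Also open, on these data alone, is whether an amine or a carboxylic acid on this ring, or a longer alkyl chain in place of the ring, would bring a value clearly below that limit.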